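Swapping the Amine Side Chain for a Carbamoylpiperidine

The compounds below may be only part of what the source reports. "The series", "measured", "known", "first", "only" and "open" are said of these compounds alone.

Of the compounds shown here, three sharing one core have been measured in an in vitro functional assay on B300-19 cells for antagonist activity at C-C chemokine receptor type 4 (Homo sapiens), read by GTPgammaS binding, tested at 1 uM; on this read-out lower numbers stand for less inhibition and higher numbers for more inhibition at the one concentration tested (going by the name of the read-out). Compound 1 `CCNc1nc(N2CCC(N3CCCC3)CC2)nc2cc(OC)c(OC)cc12` gives 3% in this assay. Compound 2 `COc1ccc2nc(N3CCC(N4CCCC4)CC3)nc(NC3CCCCCC3)c2c1` gives 10% in this assay. Compound 3 `COc1cc2nc(NCCN3CCCCC3)nc(NC3CCCCCC3)c2cc1OC` gives 1% in this assay, the smallest of the three numbers, yet its gaps to compound 1 and to compound 2 both fall within the usual scatter of repeated measurements, so the three compounds cannot be told apart on these numbers.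

Compound 4 `COc1cc2nc(N3CCC(C(N)=O)CC3)nc(NC3CCCCCC3)c2cc1OC` has not yet been measured. It differs from compound 3 in one place: 4-carbamoylpiperidin-1-yl in place of (2-(piperidin-1-yl)ethyl)amino on an aromatic carbon. The cycloheptylamino group and the two methoxy groups of the shared core are untouched, and the entering group has the same heavy-atom count, the same number of hydrogen-bond donors and the same number of hydrogen-bond acceptors as the group it replaces.

Within the data shown here, no step between two measured compounds is available here, so there is no directly comparable change to lean on. Every number shown sits close to zero, so compound 4 is expected to do likewise, with a step of a number 4 percentage points higher from compound 3 to compound 4 (within the scatter) expected to be none beyond the scatter. Compound 4 is estimated at 5% in this assay, within a range from -10% to 25%.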

Compound 4, a percentage reported as inhibition, at one concentration (the size of the read-out at that concentration, not a potency): 17%
Beside the measured number, compound 4's estimate is 12 percentage points below it; the measured number falls inside the stated range.
By their numbers in this assay, from the lowest: compounds 3, 1, 2 and 4 (each within the scatter of the next, the first and the last beyond it).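

In this assay, among these compounds, the change on the aromatic carbon between two ring nitrogen atoms brings a number 16 percentage points higher from compound 3 to compound 4 (beyond the scatter), the first step that can be read and the first sign that this position responds to the group it carries. The step is modest, and since it comes from a single tested concentration it gives no potency. The leaving and entering groups have the same counts of heavy atoms, hydrogen-bond donors and hydrogen-bond acceptors, so those counts do not separate them, and nothing shown here accounts for the step.

The swap alters both the link to the shared core and the far end of the side chain, so the compounds shown cannot say whether the directly attached piperidine ring or the carbamoyl group matters more. On these data alone, a carboxylic acid, a nitrile or a primary amine in place of the carbamoyl group would help separate these two parts, and it remains open whether a longer chain between the piperidine ring and the carbamoyl group would change the reading.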